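Cyclobutyloxy in place of pyrimidin-2-yl: expected potency

This account rests on a few compounds, and the source may have more. Where it says the series, first, only, none or still open, it means among the compounds named here.

Measured compounds, inhibition constants:
Compound 1 `Cc1cccc(-c2ccc(NC[C@H]3CC[C@]4(CC3)CN(c3cccnn3)C(=O)O4)nc2)n1` gives 0.251 nM in a functional assay for antagonist activity at Neuropeptide Y receptor type 5 (Homo sapiens); a lower number here means a stronger inhibitor, a higher number a weaker inhibitor.
Compound 2 `O=C1O[C@]2(CC[C@H](CNc3ccn(-c4ccccc4F)n3)CC2)CN1c1ccccn1` gives 0.0316 nM in this assay.
Compound 3 `O=C1O[C@]2(CC[C@H](CNc3ccc(-c4ncccn4)cn3)CC2)CN1c1ccccn1` gives 0.159 nM in this assay.

Compound 3 holds the second highest of the three numbers. Its nearest neighbour is compound 1, whose number sits within the scatter of it, so the two cannot be ordered; compound 2 gives a clearly lower number, beyond the scatter. All three share the same spirocyclic core and differ only in the aryl amine portion.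

Compound 4 `O=C1O[C@]2(CC[C@H](CNc3ccc(OC4CCC4)cn3)CC2)CN1c1ccccn1` has not been measured. Relative to compound 3 the change is cyclobutyloxy in place of pyrimidin-2-yl on an aromatic carbon. Among the compounds with values here, no measured pair in this set carries this change, so its size is not known from the series. Replacing one six-membered aromatic ring by a small saturated ether is expected to shift the number in this assay by a small to moderate amount, most probably upward, with a step within the scatter also plausible. Compound 4 is therefore expected at 0.35 nM, with a range from 0.08 nM to 1.5 nM. This corresponds to an expected step of a 2.2-fold higher number from compound 3 to compound 4 (0.34 log units; beyond the scatter).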

Compound 4, inhibition constant: 0.159 nM
Estimate against measurement, compound 4: 2.2-fold (0.34 log units) above; low and high end bracket the measured number.
By their numbers in this assay, from the lowest: compound 2; then compounds 3, 4 and 1 (each within the scatter of the next).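

In this assay, replacing pyrimidin-2-yl with cyclobutyloxy on this aromatic carbon, para to a large group, gives no change at the digits printed from compound 3 to compound 4 (within the scatter). Within the data shown here, this is the first single-place comparison, and it shows that a six-membered aromatic ring with 2 hetero atoms is not required here: a four-membered non-aromatic ring of carbon only, attached through oxygen, reads the same within the scatter. Nothing available explains why these two different groups give matching numbers.

As far as these compounds go, it remains open whether this tolerance extends to other groups at this position, such as an amine, a carboxylic acid or a longer alkoxy chain. It is also unknown whether the same exchange would read alike on the core of compound 1, which carries a different ring on the shared core.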